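The compounds below may be only part of what the source reports. "The series", "measured", "known", "first", "only" and "open" are said of these compounds alone.

Of the compounds shown here, three sharing one core have been tested in an assay for inhibition of Dihydrofolate reductase (Gallus gallus); on this read-out lower numbers stand for stronger inhibition and higher numbers for weaker inhibition. Compound 2 `Nc1ncc(Cc2ccccc2O)c(N)n1` gives 89100 nM, the highest of the three numbers. Compound 1 `COCc1ccccc1Cc1cnc(N)nc1N` gives 39800 nM, and compound 3 `Nc1ncc(Cc2ccccc2Cl)c(N)n1` gives 17400 nM. Putting hydroxy in place of methoxymethyl gave a 2.2-fold higher number from compound 1 to compound 2 (0.35 log units; beyond the scatter), putting chloro in place of methoxymethyl gave a 2.3-fold lower number from compound 1 to compound 3 (0.36 log units; beyond the scatter), and putting chloro in place of hydroxy gave a 5.1-fold lower number from compound 2 to compound 3 (0.71 log units; beyond the scatter). So the free hydroxy stands with the weakest inhibition seen so far, and every change away from it has lowered the number.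

Compound 4 `Nc1ncc(Cc2ccccc2OCc2ccccc2)c(N)n1` has not yet been measured. It differs from compound 2 by benzyl in place of hydrogen on an oxygen on an aromatic ring. The two steps that touch the hydroxy bear on this change: in compound 3 chloro in place of hydroxy gave a 5.1-fold lower number from compound 2 to compound 3 (0.71 log units; beyond the scatter), and in compound 1 an ether-type group, methoxymethyl, stood with a lower number than hydroxy, a 2.2-fold higher number from compound 1 to compound 2 (0.35 log units; beyond the scatter) in the reverse direction. Covering the hydroxy with benzyl is therefore expected to lower the number by a modest step, a 4.5-fold lower number from compound 2 to compound 4 (0.65 log units; beyond the scatter), not to leave it unchanged. The estimate for compound 4 in this assay is 20000 nM, with a range from 6000 nM to 60000 nM.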

Compound 4, inhibition constant: 9120 nM
Estimate against measurement, compound 4: 2.2-fold (0.34 log units) above; the range from low to high includes it.
By their numbers in this assay, from the lowest: compounds 4 and 3 (each within the scatter of the next); then compound 1; then compound 2.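

In this assay, a 9.8-fold lower number from compound 2 to compound 4 (0.99 log units; beyond the scatter), and here the oxygen stays on the aromatic ring while only the hydrogen on it is replaced. The earlier steps shown here swapped the whole hydroxy for another group, so they could not show whether the high number of compound 2 goes with the oxygen itself or with its hydrogen; this step shows that the oxygen can stay and the number still falls, as long as that hydrogen is gone. It also shows that a benzyl group of 7 heavy atoms, with its own six-membered aromatic ring, can sit on this oxygen without raising the number, and compound 4 ends within the scatter of compound 3 at 17400 nM.

Going by these compounds, whether the drop goes with losing the hydrogen or with gaining the aromatic ring stays open, and a methyl or a longer chain such as propyl on the same oxygen, with no ring in it, would help to tell the two apart. The compounds shown also give no reason why the number falls, so that question remains unanswered.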